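Trifluoromethyl for methyl: an expected antiproliferative step

A few compounds are considered here, and "the series" means these few. Any claim that something is new, unique, unknown or untested is made for them only; others in the source may bear on it.

Among the measured compounds shown here, in a functional assay on Jurkat cells (Homo sapiens) for antiproliferative activity, read by MTT assay, with a stated time of 72 h (a higher number here means a weaker inhibitor, a lower number a stronger inhibitor), compound 2 `COc1cc(-c2nc(C)sc2-c2ccc(C)cc2)cc(OC)c1OC` gives 517 nM, the only true number so far. Compound 1 `COc1cc(-c2nc(N(C)C)sc2-c2ccc(C(F)(F)F)cc2)cc(OC)c1OC` gives > 10000 nM, which is a limit of the assay and not a number. Compound 3 `COc1cc(-c2nc(C)sc2-c2ccc(C(F)(F)F)cc2)cc(OC)c1OC` keeps the core of compound 2 and changes a single group: trifluoromethyl in place of methyl on an aromatic carbon. For the measured compounds named here, no measured pair of compounds isolates this change, so any prediction rests on thin evidence. Differing from compound 2 in a second place as well, compound 1 also carries trifluoromethyl, and its limit of > 10000 nM offers only a weak hint towards weaker inhibition. In this assay, a moderate loss beyond the usual scatter is therefore expected, an estimated 2.9-fold higher number from compound 2 to compound 3 (0.46 log units; beyond the scatter). Compound 3 is expected at 1500 nM, with an estimated range of 350 nM to 8000 nM.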

Compound 3, half-maximal inhibitory concentration: 7110 nM
Compound 3: middle estimate off by 4.7-fold (0.68 log units), on the low side; low and high end bracket the measured number.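

Trifluoromethyl in place of methyl, on an aromatic carbon para to a large group, now has its first clean test, and in this assay the change costs a great deal: a 14-fold higher number from compound 2 to compound 3 (1.14 log units; beyond the scatter). Compound 3 also allows a comparison at the other place that changes, though only a loose one: an at least 1.4-fold lower number from compound 1 to compound 3 (0.14 log units; that floor lies within the scatter). Because the value for compound 1 is a limit of the assay and not a number, that step gives only a floor, and the effect of methyl in place of dimethylamino cannot be judged: the limit of > 10000 nM in this assay, at which 1 of the 3 values shown sits.

As far as these compounds go, it remains open whether a hydrogen, a chlorine atom or a methoxy group on this aromatic carbon would stay close to compound 2 or fall towards compound 3. From the compounds shown here alone, it is also open how a longer chain in place of the other methyl of compound 3 would behave.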